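This account rests on a few compounds, and the source may have more. Where it says the series, first, only, none or still open, it means among the compounds named here.

Compound 1 `CC(C)COc1ccccc1-c1ncc(C(=O)O)c(=O)[nH]1` carries a free carboxylic acid on its core. In a functional assay on the whole organism (strain Sprague-Dawley) for inhibition, with Rattus norvegicus as the target, with a stated time of 10 min (a higher number here means that more compound is needed for the effect, a lower number that less compound is needed), compound 1 gives 0.5 mg/kg. Compound 3 `CCOC(=O)c1cnc(-c2ccccc2OCC(C)C)[nH]c1=O` is its ethyl ester: the change from one to the other is ethyl in place of hydrogen on an oxygen next to a carbonyl group, and the step it made in this assay was a 6.0-fold higher number from compound 1 to compound 3 (0.78 log units; beyond the scatter). In this assay compound 3 gives 3 mg/kg. Compound 2 `O=C(O)c1cnc(-c2cccc(C(F)(F)F)c2)[nH]c1=O` keeps the free carboxylic acid but sits on a core with a different aryl group; the difference between the two cores is not broken down here. In this assay compound 2 gives 33 mg/kg, the highest of the three numbers, and its gaps to compound 3 and to compound 1 both lie beyond the scatter.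

Compound 4 `CCOC(=O)c1cnc(-c2cccc(C(F)(F)F)c2)[nH]c1=O` has not yet been measured in this assay. It differs from compound 2 by ethyl in place of hydrogen on an oxygen next to a carbonyl group, the same change, at the same place, that turned compound 1 into compound 3. The change has been seen only once, so the expectation rests on that one step. Among the measured compounds shown here, because the earlier step was a 6.0-fold higher number from compound 1 to compound 3 (0.78 log units; beyond the scatter), the expected step here is a 4.5-fold higher number from compound 2 to compound 4 (0.66 log units; beyond the scatter), with wide room on either side since a single instance on a different core is the only guide. For compound 4 the estimated dose in this assay is therefore 150 mg/kg, expected to fall between 40 mg/kg and 600 mg/kg.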

Compound 4, dose for 50% inhibition: 50 mg/kg
Compound 4: middle estimate off by 3.0-fold (0.48 log units), on the high side; low and high end bracket the measured number.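

On the core of compound 2, the change from carboxy to ethoxycarbonyl gave, in this assay, a 1.5-fold higher number from compound 2 to compound 4 (0.18 log units; within the scatter), so on this core the free acid and its ethyl ester cannot be told apart, whereas on the core of compound 1 they can. The size of the step therefore did not carry over from one core to the other: the same change on two cores in this assay, a 6.0-fold higher number (0.78 log units; beyond the scatter) from compound 1 to compound 3 and a 1.5-fold higher number (0.18 log units; within the scatter) from compound 2 to compound 4, 4.0-fold (0.60 log units) apart, beyond the scatter of two such steps. Among the compounds shown here, this shows that, in these two pairs, a step seen on one core was a poor guide to its size on the other, but with only two cores it does not show which feature of the cores sets the size, nor what the same change would do on a third core.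

The compounds shown leave open whether a methyl ester, an ester with a longer chain or an amide in place of the ethyl ester would show the same dependence on the core. Also open, on these data alone, is how the same change behaves on cores whose aryl group carries something else, such as a nitrile or an amine, which would show whether the two pairs here are the ends of a range or simply two separate cases.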